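The source may hold more compounds than are shown below. What is called first, only, known or untested is meant among the compounds shown, and "the series" means these compounds.

Compound 1 `COc1cc(-c2cc(/C=C/C(=O)c3ccc(Cl)c(Cl)c3)[nH]n2)cc(OC)c1OC` and compound 2 `COc1ccc(C(=O)/C=C/c2cc(-c3cc(OC)c(OC)c(OC)c3)n[nH]2)cc1OC` share one core and differ only in the aryl group on the carbonyl carbon. In a functional assay on HOP-62 cells (Homo sapiens) for cytotoxicity, read by sulforhodamine B assay, with a stated time of 48 h, tested at 0.1 uM (on this read-out higher numbers stand for a weaker effect at the one concentration tested and lower numbers for a stronger effect), compound 1 gives 101%, and in this assay compound 2 gives 100%. Going by the values given here, the step of a number 1 percentage points lower from compound 1 to compound 2 (within the scatter) leaves compound 2 within the scatter of the only other number, so no order between them is claimed. Compound 3 `COc1cc(-c2cc(/C=C/C(=O)c3ccc(F)c(F)c3)[nH]n2)cc(OC)c1OC` differs from compound 2 by 3,4-difluorophenyl in place of 3,4-dimethoxyphenyl on a carbonyl carbon. Among the compounds with values here, the single step that bears on this, a number 1 percentage points lower from compound 1 to compound 2 (within the scatter), stayed flat, so the step to compound 3 is expected to be no change at the digits printed from compound 2 to compound 3 (within the scatter), none beyond the scatter. Compound 3 is accordingly estimated at 100%, within a range from 88% to 110%.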

Compound 3, a percentage reported as activity, at one concentration (the size of the read-out at that concentration, not a potency): 101%
Compound 3: middle estimate off by 1 percentage points, on the low side; the measured number falls inside the stated range.
By their numbers in this assay, from the lowest: compounds 2, 1 and 3 (each within the scatter of the next).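

In this assay, 3,4-difluorophenyl in place of either earlier group on a carbonyl carbon gives no separation (a number 1 percentage points higher from compound 2 to compound 3 (within the scatter); no change at the digits printed from compound 1 to compound 3 (within the scatter)). A third aryl group, with 0 hydrogen-bond acceptors where 3,4-dimethoxyphenyl has 2, thus joins the other two without any readable difference at this one concentration. No evidence is given that would account for this. From the compounds shown here alone, it stays open whether a phenyl carrying an amine or a carboxylic acid at this place would separate from these three. Going by these compounds, whether the three would stay together at another concentration also stays open.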